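This account rests on a few compounds, and the source may have more. Where it says the series, first, only, none or still open, it means among the compounds named here.

Four related small molecules are in view here. In an ADME assay on MDCK cells (Canis lupus familiaris) for cytotoxicity, read by MTT assay, with a stated time of 24 h (a higher number here means that more compound is tolerated, a lower number that less compound is tolerated), compound 1 (`Cc1cc(CNS(=O)(=O)c2ccc(Br)cc2)c(C)o1`) gives 29600 nM. In this assay, compound 2 (`Cc1cc(CNS(=O)(=O)c2ccc(F)cc2)c(C)s1`) stands as "not determined" (no result reported). In this assay, compound 3 (`N#Cc1ccc(S(=O)(=O)NCc2cc3ccccc3s2)cc1`) also stands as "not determined" (no result reported), so it has no single number and cannot be placed above or below compound 1.

Compound 4 (`Cc1ccc(S(=O)(=O)NCc2cc3ccccc3s2)cc1`) has yet to be measured. Its structure departs from that of compound 3 in one place: methyl in place of cyano on an aromatic carbon. In words, this is methyl in place of cyano on an aromatic carbon, para to a large group.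

Among the measured compounds shown here, no pair of measured compounds here differs in just one place, so the data show nothing about how large such a change tends to be in this assay. With nothing to point either way, the expectation is no step beyond the usual scatter, and no direction is predicted. For the measured compounds named here, the only numerical anchor is compound 1 at 29600 nM, and it differs from compound 4 in more than one place, so the range has to stay wide. For compound 4 the estimated half-maximal cytotoxic concentration is 30000 nM, with an expected range of 9000 nM to 100000 nM.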

Compound 4, half-maximal cytotoxic concentration: > 210000 nM
Compound 4 ended at the assay's limit (the forecaster's own chance of this, stated with the estimate: 35%); middle value at least 7.0-fold (0.84 log units) away from the limit.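

In this assay compound 4 gives > 210000 nM, which is a limit of the assay and not a number. Among the compounds shown here, compound 3 has no single number there, so no step between compound 3 and compound 4 can be read. The compounds shown leave open how far methyl in place of cyano shifts the half-maximal cytotoxic concentration in this assay.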